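A few compounds are considered here, and "the series" means these few. Any claim that something is new, unique, unknown or untested is made for them only; others in the source may bear on it.

Working notes on the series.

Among the measured compounds shown here, the two measured members share a core carrying a pentyl chain and a urea-type side chain. Compound 1 `CCCCCc1cccc(NC(=O)NCCCCl)c1` gives in a functional assay on HT-29 cells (Homo sapiens) for antiproliferative activity, with a stated time of 48 h (a lower number here means a stronger inhibitor, a higher number a weaker inhibitor), a value of 28000 nM. Compound 2 `CCCCCc1cccc(NC(=O)NC(=O)CCl)c1` gives in this assay a value of 8400 nM. For the measured compounds named here, the single measured step, a 3.3-fold lower number from compound 1 to compound 2 (0.52 log units; beyond the scatter), is the only piece of structure-activity information so far, and on these two numbers compound 2 stands lowest, with compound 1 the only comparator above it.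

Compound 3 `CCCCCc1cccc(NC(=O)CCCCl)c1` is the next point. Relative to compound 2 the change is 3-chloropropyl in place of ((chloromethyl)carbonyl)amino on a carbonyl carbon. Going by the values given here, no measured step covers this exact change: the step from compound 1 to compound 2 altered the group on the amide-type nitrogen, whereas here the whole ((chloromethyl)carbonyl)amino unit is replaced and the 3-chloropropyl chain returns, now attached directly to the carbonyl carbon. Given that the one known step was modest, a shift in either direction of similar or smaller size is plausible, with a drift back towards the compound 1 level slightly favoured. Compound 3 is therefore expected to give in this assay about 15000 nM, within 4000 nM to 60000 nM, which corresponds to an estimated step of a 1.8-fold higher number from compound 2 to compound 3 (0.25 log units; within the scatter).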

Compound 3, half-maximal inhibitory concentration: > 100000 nM
Compound 3 ended at the assay's limit (the forecaster's own chance of this, stated with the estimate: 10%); middle value at least 6.6-fold (0.82 log units) from the limit.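

Compound 3 gives a limit in this assay, not a number: the limit of > 100000 nM in this assay, at which 1 of the 3 values shown sits.

Among the compounds shown here, until now, the only change lay on the amide-type nitrogen and gave a modest step; replacing ((chloromethyl)carbonyl)amino on the carbonyl carbon gives a far larger one, an at least 11-fold higher number from compound 2 to compound 3 (1.07 log units; beyond the scatter). The comparison with compound 1 is the cleaner one, since 3-chloropropyl in place of (3-chloropropyl)amino on the carbonyl carbon removes only the amino nitrogen and still gives an at least 3.5-fold higher number from compound 1 to compound 3 (0.55 log units; beyond the scatter), so among these three compounds the two that keep this nitrogen give numbers in this assay, while compound 3, which lacks it, gives only a limit.

Going by these compounds, how far compound 3 really lies from the other two stays unknown, and these compounds do not separate the role of the nitrogen from that of the chain attached to the carbonyl carbon. Also open, on these data alone, is whether an oxygen atom in place of this nitrogen, a longer chain, or a bromine atom or an unsubstituted propyl chain in place of the chlorine-bearing chain would keep the numbers of compound 1 and compound 2.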